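Disubstituted Amide Aryl Groups on a Shared Flavone Core

The source may report more compounds than this note shows. Statements on the series, on what has been measured and on what is new or still open speak of the compounds shown alone.

Measured compounds:
compound 1 `Cc1ccc(C(=O)Nc2cccc(-c3oc4cc(-c5ccc(F)cc5)ccc4c(=O)c3O)c2)cc1`: 6910 nM
compound 2 `Cc1cccc(C(=O)Nc2cccc(-c3oc4cc(-c5ccc(F)cc5)ccc4c(=O)c3O)c2)c1`: 16500 nM
compound 3 `COc1cc(OC)cc(C(=O)Nc2cccc(-c3oc4cc(-c5ccc(F)cc5)ccc4c(=O)c3O)c2)c1`: 2390 nM

In a functional assay on A549 cells (Homo sapiens) for antiproliferative activity, read by CCK-8 assay, with a stated time of 72 h (on this read-out higher numbers stand for weaker inhibition and lower numbers for stronger inhibition), compound 1 gives 6910 nM, the second highest of the three numbers. The nearest neighbour is compound 2 with a 2.4-fold higher number from compound 1 to compound 2 (0.38 log units; beyond the scatter); the furthest is compound 3 with a 2.9-fold lower number from compound 1 to compound 3 (0.46 log units; beyond the scatter). Compound 4 `O=C(Nc1cccc(-c2oc3cc(-c4ccc(F)cc4)ccc3c(=O)c2O)c1)c1cc(F)cc(F)c1` differs from compound 1 in one place: 3,5-difluorophenyl in place of 4-methylphenyl on a carbonyl carbon. Going by the values given here, of the measured steps, the one from compound 1 to compound 3 is the closest analogy, since it also places two groups on that ring, and it lowered the number modestly; the step to compound 2 went the other way. The estimate for compound 4 therefore means a 1.7-fold lower number from compound 1 to compound 4 (0.24 log units; within the scatter), a modest lowering that could fall within the scatter. Compound 4 is expected to give about 4000 nM, within 1500 nM to 11000 nM.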

Compound 4, half-maximal inhibitory concentration: 7620 nM
Compound 4: middle estimate off by 1.9-fold (0.28 log units), on the low side; measured number inside the range.
By their numbers in this assay, from the lowest: compound 3; then compounds 1 and 4 (each within the scatter of the next); then compound 2.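

In this assay, 3,5-difluorophenyl in place of 4-methylphenyl gives a 1.1-fold higher number from compound 1 to compound 4 (0.04 log units; within the scatter), so placing two groups on this ring does not by itself reproduce the low number of compound 3. The groups themselves separate: 3,5-difluorophenyl in place of 3,5-dimethoxyphenyl gives a 3.2-fold higher number from compound 3 to compound 4 (0.50 log units; beyond the scatter), while in place of 3-methylphenyl it gives a 2.2-fold lower number from compound 2 to compound 4 (0.34 log units; beyond the scatter). Nothing available here explains these differences. Still open, going by these compounds, is how a phenyl ring carrying an amine or a carboxylic acid would read on this carbonyl carbon, and whether a longer chain could replace the ring.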